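The source may report more compounds than this note shows. Statements on the series, on what has been measured and on what is new or still open speak of the compounds shown alone.

Three sulfonamides built on one shared core differ only at a single aromatic carbon. Compound 1 `CC(C)(C)c1ccc(S(=O)(=O)Nc2ccccc2O)cc1` gives 1230 nM in an assay on HEK293 cells for inhibition of 17-beta-hydroxysteroid dehydrogenase type 2 (Homo sapiens), read by scintillation counting, with a stated time of 10 min, in the presence of a further agent that is not named here; a higher number here means a weaker inhibitor, a lower number a stronger inhibitor. Compound 2 `Cc1ccc(O)c(NS(=O)(=O)c2ccc(C(C)(C)C)cc2)c1` gives 4090 nM in this assay, and compound 3 `CC(C)(C)c1ccc(S(=O)(=O)Nc2cc(Cl)ccc2O)cc1` gives 800 nM there. Compound 3 holds the lowest of the three numbers, but the step of a 1.5-fold lower number from compound 1 to compound 3 (0.19 log units; within the scatter) is within the scatter, while the step of a 5.1-fold lower number from compound 2 to compound 3 (0.71 log units; beyond the scatter) lies beyond it. The unmeasured compound 4 `CC(C)(C)c1ccc(S(=O)(=O)Nc2cc(-c3ccccc3)ccc2O)cc1` differs from compound 3 by phenyl in place of chloro on an aromatic carbon, at the carbon meta to a large group and para to a hydroxy group. All three measured steps concern this same carbon: a chloro for hydrogen a 1.5-fold lower number from compound 1 to compound 3 (0.19 log units; within the scatter), a methyl for hydrogen a 3.3-fold higher number from compound 1 to compound 2 (0.52 log units; beyond the scatter), and a chloro for methyl a 5.1-fold lower number from compound 2 to compound 3 (0.71 log units; beyond the scatter). Among the measured compounds shown here, none of them introduces a phenyl, so the step to compound 4 has no direct precedent. The measured steps show this position accepts a chloro without penalty yet turns a methyl into a modest loss, so a modest weakening is the most likely outcome, with wide uncertainty. Compound 4 is therefore expected at 1500 nM in this assay, in a range from 400 nM to 6000 nM. That estimate implies a step of a 1.9-fold higher number from compound 3 to compound 4 (0.27 log units; within the scatter), expected rather than measured.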

Compound 4, half-maximal inhibitory concentration: 1250 nM
The estimate for compound 4 lay 1.2-fold (0.08 log units) above the measured number; low and high end bracket the measured number.
By their numbers in this assay, from the lowest: compounds 3, 1 and 4 (each within the scatter of the next); then compound 2.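

In this assay the carbon para to a hydroxy group takes a phenyl, with its 6 heavy atoms in place of the 1 of chloro, and the printed steps stay within the scatter: a 1.6-fold higher number from compound 3 to compound 4 (0.19 log units; within the scatter) and a 1.0-fold higher number from compound 1 to compound 4 (0.01 log units; within the scatter) leave hydrogen, chloro and phenyl unseparated at this carbon. The weaker number of the methyl compound therefore does not extend into a trend with the heavy-atom count of the group, and compound 2 goes against any such reading, as a 3.3-fold lower number from compound 2 to compound 4 (0.51 log units; beyond the scatter) lies beyond the scatter even though the phenyl is the larger group. Nothing given here accounts for why the methyl alone stands apart from the hydrogen, the chloro and the phenyl.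

The compounds shown leave open whether the methyl result is particular to that group or would recur with an ethyl or a methoxy group at this carbon. They also leave open whether a group of another kind there, such as an amine, a carboxylic acid or a cyclohexyl ring, would fall with the hydrogen, chloro and phenyl compounds or with the methyl compound.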